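The compounds below may be only part of what the source reports. "The series", "measured", "known", "first", "only" and "open" are said of these compounds alone.

Measured in an assay for inhibition of Fatty-acid amide hydrolase 1 (Rattus norvegicus); on this read-out higher numbers stand for weaker inhibition and lower numbers for stronger inhibition: compound 1 `O=C(CCCCCCc1ccccc1Cl)c1ncc(-c2ccccn2)o1` gives 1.9 nM; compound 2 `Nc1cccc(CCCCCCC(=O)c2ncc(-c3ccccn3)o2)c1` gives 30 nM; compound 3 `CSc1ccc(CCCCCCC(=O)c2ncc(-c3ccccn3)o2)cc1` gives 2.5 nM.

Compound 3 stands second highest of the three numbers. The step of a 1.3-fold higher number from compound 1 to compound 3 (0.12 log units; within the scatter) lies within the scatter, whereas a 12-fold lower number from compound 2 to compound 3 (1.08 log units; beyond the scatter) is large. Compound 4 `CN(CCCCCC(=O)c1ncc(-c2ccccn2)o1)c1ccccc1` is not yet measured; it differs from compound 3 in one place: methyl(phenyl)amino in place of 4-(methylsulfanyl)benzyl on a saturated chain carbon, five bonds along the chain from a carbonyl carbon. Among the compounds with values here, no measured step makes this exact change. The nearest comparisons are aryl swaps on a saturated chain carbon, six bonds along the chain from a carbonyl carbon: a 16-fold higher number from compound 1 to compound 2 (1.20 log units; beyond the scatter) and a 1.3-fold higher number from compound 1 to compound 3 (0.12 log units; within the scatter), spanning within the scatter to large. A moderate weakening is therefore expected for compound 4, a 3.2-fold higher number from compound 3 to compound 4 (0.51 log units; beyond the scatter). Compound 4 is estimated at 8 nM, range 2 nM to 40 nM.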

Compound 4, inhibition constant: 40 nM
For compound 4 the middle estimate is 5.0-fold (0.70 log units) below the measured one; the range from low to high includes it.
By their numbers in this assay, from the lowest: compounds 1 and 3 (each within the scatter of the next); then compounds 2 and 4 (each within the scatter of the next).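

In this assay, methyl(phenyl)amino on this saturated chain carbon, five bonds along the chain from a carbonyl carbon, gives a 16-fold higher number from compound 3 to compound 4 (1.20 log units; beyond the scatter) and a 21-fold higher number from compound 1 to compound 4 (1.32 log units; beyond the scatter), so a side group with a nitrogen joined to the chain falls well out of line with the 2-chlorobenzyl and 4-(methylsulfanyl)benzyl compounds. Against 3-aminobenzyl, the change gives a 1.3-fold higher number from compound 2 to compound 4 (0.12 log units; within the scatter), which places compound 4 with compound 2. Nothing measured here explains these steps.

Still open, from the compounds shown here alone, is whether the step follows the chain-linked nitrogen or its methyl. Phenylamino and unsubstituted benzyl would separate the two.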